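This account rests on a few compounds, and the source may have more. Where it says the series, first, only, none or still open, it means among the compounds named here.

Of the compounds shown here, three sharing one core have been measured in a functional assay on PC-3 cells (Homo sapiens) for inhibition, read by sulforhodamine B assay, with a stated time of 72 h; on this read-out higher numbers stand for weaker inhibition and lower numbers for stronger inhibition. Compound 1 `Nc1sc(-c2ccc(Cl)cc2)c(-c2ccc(Cl)cc2)c1C(=O)NC1CCCCC1` gives 7300 nM, compound 2 `CC1CCN(C(=O)c2c(N)sc(-c3ccc(Cl)cc3)c2-c2ccc(Cl)cc2)CC1` gives 5750 nM, and compound 3 `Nc1sc(-c2ccc(Cl)cc2)c(-c2ccc(Cl)cc2)c1C(=O)NC1CCC(O)CC1` gives 5670 nM. These values all lie within the scatter of each other, so compound 2 does not stand apart from the other two. Compound 4 `CC(C)(C)NC(=O)c1c(N)sc(-c2ccc(Cl)cc2)c1-c1ccc(Cl)cc1` differs from compound 2 in one place: (tert-butyl)amino in place of 4-methylpiperidin-1-yl on a carbonyl carbon. In words, (tert-butyl)amino sits in place of 4-methylpiperidin-1-yl on a carbonyl carbon. For the measured compounds named here, no measured step makes exactly this exchange, and no group without a ring has been measured here at that carbon. The closest evidence comes from two other exchanges at the same carbon, a 1.3-fold lower number from compound 1 to compound 2 (0.10 log units; within the scatter) and a 1.0-fold lower number from compound 2 to compound 3 (0.01 log units; within the scatter), both within the scatter. Adding hydroxy on a saturated ring carbon, a 1.3-fold lower number from compound 1 to compound 3 (0.11 log units; within the scatter), also stayed within the scatter. On this evidence, no step beyond the scatter is expected in this assay, in either direction. The expected step is only a 1.0-fold higher number from compound 2 to compound 4 (0.02 log units; within the scatter). For compound 4 the estimated value is 6000 nM, with an expected range of 3300 nM to 11000 nM.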

Compound 4, half-maximal inhibitory concentration: 15100 nM
Compound 4: middle estimate off by 2.5-fold (0.40 log units), on the low side; measured number above the stated range.
By their numbers in this assay, from the lowest: compounds 3, 2 and 1 (each within the scatter of the next); then compound 4.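

For the compounds shown here, at this carbonyl carbon, the earlier compounds made the group look freely exchangeable, but in this assay the first group without a ring gives a weaker result, with steps beyond the scatter against all three ring-bearing amides (a 2.6-fold higher number from compound 2 to compound 4 (0.42 log units; beyond the scatter)) (a 2.7-fold higher number from compound 3 to compound 4 (0.43 log units; beyond the scatter)) (a 2.1-fold higher number from compound 1 to compound 4 (0.32 log units; beyond the scatter)). The amide hydrogen does not set compound 4 apart: compound 1 and compound 3 also carry it and compound 2 lacks it, yet those three lie within the scatter of one another. No measurement here explains why tert-butyl behaves differently.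

On these data alone, it remains open whether this loss goes with the missing ring or with the branched shape of tert-butyl. A straight butyl chain or a cyclopropyl ring on the amide nitrogen would help separate the two.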